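Swapping Furan for Thiophene in a Lipase Inhibitor Series

This account rests on a few compounds, and the source may have more. Where it says the series, first, only, none or still open, it means among the compounds named here.

Measured so far:
- compound 1, `Cc1c(C(C)(C)C)c(=O)on1C(=O)N1CCCCC1`: 14 nM
- compound 2, `Cc1c(C(C)C)c(=O)on1C(=O)N(C)Cc1ccc(F)cc1`: 111 nM
- compound 3, `Cc1c(C(C)C)c(=O)on1C(=O)N(C)Cc1ccco1`: 4 nM

All three compounds share a common core and were tested in an assay (strain Wistar) for inhibition of Hormone-sensitive lipase (Rattus norvegicus), read by spectrophotometry; a higher number here means a weaker inhibitor, a lower number a stronger inhibitor. Compound 1 gives 14 nM, compound 2 gives 111 nM and compound 3 gives 4 nM. Compound 3 is the strongest inhibitor of the three: the step to compound 1 and the step to compound 2 both lie beyond the scatter, so this is a real difference and not noise.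

The next compound, compound 4 with the structure `Cc1c(C(C)C)c(=O)on1C(=O)N(C)Cc1cccs1`, differs from compound 3 in one place: thiophen-2-yl in place of furan-2-yl on a saturated chain carbon bound to an amide-type nitrogen.

Going by the values given here, only one measured step touches this position. a 28-fold lower number from compound 2 to compound 3 (1.44 log units; beyond the scatter) shows that the group on this carbon can move the number a great deal. That step, however, exchanged a six-membered ring for a five-membered one; the change from compound 3 to compound 4 keeps a five-membered aromatic ring with one hetero atom and only swaps oxygen for sulfur. Among the compounds with values here, nothing measured here tells how much that swap matters, so a smaller step than the one from compound 2 to compound 3 is expected.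

Compound 4 is therefore estimated at 8 nM in this assay, with a range from 2.5 nM to 30 nM. This estimate means a step of a 2.0-fold higher number from compound 3 to compound 4 (0.30 log units; within the scatter), expected to stay close to the scatter.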

Compound 4, half-maximal inhibitory concentration: 2 nM
Beside the measured number, compound 4's estimate is 4.0-fold (0.60 log units) above it; the measured number lies below the stated range.
By their numbers in this assay, from the lowest: compounds 4 and 3 (each within the scatter of the next); then compound 1; then compound 2.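

In this assay, exchanging furan-2-yl for thiophen-2-yl on a saturated chain carbon bound to an amide-type nitrogen gives a 2.0-fold lower number from compound 3 to compound 4 (0.30 log units; within the scatter) and so leaves the two rings impossible to tell apart, which means that oxygen and sulfur serve equally well as the ring hetero atom here. Thiophen-2-yl also keeps the large advantage over 4-fluorophenyl, with a 56-fold lower number from compound 2 to compound 4 (1.74 log units; beyond the scatter) as its step, which is comparable in class to a 28-fold lower number from compound 2 to compound 3 (1.44 log units; beyond the scatter) and shows that the earlier large step does not depend on the oxygen of furan-2-yl. Two different five-membered aromatic rings with one hetero atom now sit together at the low end of this comparison, while compound 2, with its six-membered ring, stands apart from both.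

Nothing available explains why the two five-membered rings match each other or why both differ so much from 4-fluorophenyl. The compounds shown also leave open whether the large step follows the ring size or the fluorine, a question that a plain phenyl ring without fluorine at this position would help to separate.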